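The source may hold more compounds than are shown below. What is called first, only, known or untested is meant among the compounds shown, and "the series" means these compounds.

Within the data shown here, in a functional assay on Coronary artery (Bos taurus) (on this read-out lower numbers stand for an effect already at smaller amounts and higher numbers for an effect only at larger amounts of compound), compound 1 (`CCCCCNC(=O)NCCCC/C=C\CCCCCSc1nnn[nH]1`) gives 3700 nM and compound 2 (`CCCCCNC(=O)NCCCC/C=C\CCCCCCCc1nnn[nH]1`) gives 1100 nM, the lower of the two numbers so far. Among the measured compounds shown here, the only measured step, a 3.4-fold lower number from compound 1 to compound 2 (0.53 log units; beyond the scatter), is modest but beyond the scatter. It places 2-(1H-tetrazol-5-yl)ethyl where (1H-tetrazol-5-yl)sulfanyl stood, so the tetrazole ring itself stays. Compound 3 (`CCCCCNC(=O)NCCCC/C=C\CCCCCCC1=NOS(=O)N1`) changes that ring: a group of 6 heavy atoms (1 carbon, 2 nitrogen, 2 oxygen, 1 sulfur; one five-membered non-aromatic ring with 4 hetero atoms) in place of a group of 6 heavy atoms (2 carbon, 4 nitrogen; one five-membered aromatic ring with 4 hetero atoms), on a saturated chain carbon, six bonds along the chain from a double-bonded chain carbon. The new group is a five-membered non-aromatic ring, on a saturated chain carbon, six bonds along the chain from a double-bonded chain carbon. For the measured compounds named here, no measured pair replaces the ring, so the modest step above offers only a rough guide to size, and the direction remains open. A modest rise is tentatively expected, with the estimated change being a 1.4-fold higher number from compound 2 to compound 3 (0.13 log units; within the scatter). For compound 3, the expected value is 1500 nM, with an estimated range from 400 nM to 6000 nM.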

Compound 3, half-maximal effective concentration: 340 nM
Beside the measured number, compound 3's estimate is 4.4-fold (0.64 log units) above it; the measured number lies below the stated range.
By their numbers in this assay, from the lowest: compound 3; then compound 2; then compound 1.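

In this assay, among these compounds, the earlier compounds kept the tetrazole ring, and this result shows that the ring can be exchanged without loss: replacing it with the five-membered non-aromatic ring with 4 hetero atoms gives a 3.2-fold lower number from compound 2 to compound 3 (0.51 log units; beyond the scatter). Among the compounds shown here, measured against the sulfanyl-linked tetrazole, the new group gives an 11-fold lower number from compound 1 to compound 3 (1.04 log units; beyond the scatter), the only large step in this short series, and compound 3 now has the lowest number of the three. Nothing available explains why the two rings differ on this read-out.

The compounds shown leave open how a carboxylic acid at this same place, on a saturated chain carbon, would compare with either ring. Going by these compounds, the shared core also stays unchanged throughout, so whether a longer chain would shift these numbers remains unknown.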